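This account rests on a few compounds, and the source may have more. Where it says the series, first, only, none or still open, it means among the compounds named here.

Measured in a functional assay on K562 cells (Homo sapiens) for antiproliferative activity, read by MTT assay, with a stated time of 72 h (a lower number here means a stronger inhibitor, a higher number a weaker inhibitor), all three values being limits:
- Compound 1 `COc1cc(-c2ncnn2-c2ccc(Cl)cc2Cl)cc(OC)c1OC`: > 10000 nM
- Compound 2 `COc1cc(-c2ncnn2-c2ccc(F)cc2)cc(OC)c1OC`: > 10000 nM
- Compound 3 `COc1cc(-c2ncnn2-c2ccc([N+](=O)[O-])cc2)cc(OC)c1OC`: > 10000 nM

Compound 3 gives no number, only the limit > 10000 nM. The same holds across the series: the limit of > 10000 nM in this assay, at which 3 of the 3 values shown sit.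

Compound 4 `COc1cc(-c2ncnn2-c2ccc(Cl)cc2)cc(OC)c1OC` has chloro in place of nitro on an aromatic carbon, para to a large group: chloro in place of nitro on an aromatic carbon.

Among the compounds with values here, two measured steps bear on this change: a step that the two limits leave unreadable from compound 2 to compound 3, which exchanges a group at the same kind of place, and a step that the two limits leave unreadable from compound 1 to compound 2. Neither has a readable size, so neither gives a direction or magnitude to carry over. Compound 1, which has 2,4-dichlorophenyl, also stands at a limit, > 10000 nM.

In this assay, no step beyond the scatter can therefore be forecast, and the most likely outcome is another limit rather than a number. The expected step is a step that the limit leaves unreadable from compound 3 to compound 4. For compound 4 the estimated value is 15000 nM, with an expected range from 6000 nM to 40000 nM.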

Compound 4, half-maximal inhibitory concentration: > 10000 nM
Compound 4: a limit, no number; the forecaster's own chance of this, stated with the estimate: 85%; the middle value is on the limit's open side.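

Compound 4 adds no readable step in this assay: it too gives only a limit, so its comparisons with compound 1, compound 2 and compound 3 cannot be read, and the series stands as follows: the limit of > 10000 nM in this assay, at which 4 of the 4 values shown sit. The compounds shown leave open which change on the shared core, if any, would give a measurable value.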